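A few compounds are considered here, and "the series" means these few. Any claim that something is new, unique, unknown or untested is made for them only; others in the source may bear on it.

In a functional assay on MCF7 cells (Homo sapiens) for inhibition, with a stated time of 72 h; a higher number here means a weaker inhibitor, a lower number a stronger inhibitor:
- Compound 1 `NC1CCC(Nc2nc(NCc3ccc(-c4cccc(F)c4)cc3)c3ncn(C4CCCC4)c3n2)CC1`: 293 nM
- Compound 2 `NC1CCC(Nc2nc(NCc3ccc(-c4ccsc4)cc3)c3ncn(C4CCCC4)c3n2)CC1`: 145 nM
- Compound 3 `NC1CCC(Nc2nc(NCc3ccc(-c4ccco4)nc3)c3ncn(C4CCCC4)c3n2)CC1`: not yet measured

Compound 2 has the lower of the two numbers, which makes it the stronger inhibitor of this pair. Compound 3 carries 6-(furan-2-yl)pyridin-3-yl in place of 4-(thiophen-3-yl)phenyl on a saturated chain carbon bound to a nitrogen on an aromatic ring.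

For the measured compounds named here, only one measured step bears on this change, and it is modest: a 2.0-fold lower number from compound 1 to compound 2 (0.31 log units; beyond the scatter). That step exchanged a single aromatic group. Here the five-membered ring changes and the six-membered ring also gains a hetero atom, which no measured compound tests. A small shift towards a higher number is therefore expected, with wide uncertainty.

The expected change is a 1.5-fold higher number from compound 2 to compound 3 (0.18 log units; within the scatter). Compound 3 is estimated at 220 nM, with an expected range of 70 nM to 650 nM.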

Compound 3, half-maximal inhibitory concentration: 33 nM
Compound 3: the middle estimate sits 6.7-fold (0.82 log units) above what was measured; measured number below the stated range.
By their numbers in this assay, from the lowest: compound 3; then compound 2; then compound 1.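

For the compounds shown here, compounds 1 and 2 showed only that swapping one aromatic group at the end of this substituent moves the number. Compound 3 shows that the whole two-ring group on the saturated chain carbon can be replaced, with nitrogen entering the six-membered ring and oxygen replacing sulfur in the five-membered ring, and that inhibition improves in this assay, with a 4.4-fold lower number from compound 2 to compound 3 (0.64 log units; beyond the scatter). Nothing available explains why the number fell.

From the compounds shown here alone, both rings changed in one step, so the shares of the furan and the ring nitrogen remain unknown. A furan on the carbon-only six-membered ring, or a thiophene on the six-membered ring with the nitrogen, would separate them, and an amine or a methoxy group on that ring remains an open question.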